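This account rests on a few compounds, and the source may have more. Where it says the series, first, only, none or still open, it means among the compounds named here.

Measured so far in a functional assay on MCF7 cells (Homo sapiens) for cytotoxicity, read by MTT assay, with a stated time of 72 h; on this read-out higher numbers stand for weaker inhibition and lower numbers for stronger inhibition:
- compound 1 `COc1ccc(/C=C/C(=O)Nc2cc3c(Nc4ccc(F)c(Cl)c4)ncnc3cc2O[C@H]2CCOC2)c(OC)c1OC`: 4650 nM
- compound 2 `COc1cc(/C=C/C(=O)Nc2cc3c(Nc4ccc(F)c(Cl)c4)ncnc3cc2O[C@H]2CCOC2)cc(OC)c1`: 30300 nM

Compound 2, at 30300 nM, holds the higher of the two numbers and so shows the weaker inhibition. The next compound, compound 3 `COc1ccc(/C=C/C(=O)Nc2cc3c(Nc4ccc(F)c(Cl)c4)ncnc3cc2O[C@H]2CCOC2)cc1`, has 4-methoxyphenyl in place of 3,5-dimethoxyphenyl on a double-bonded chain carbon bound to a double-bonded chain carbon.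

Among the compounds with values here, one measured step bears on this change: a 6.5-fold higher number from compound 1 to compound 2 (0.81 log units; beyond the scatter), a modest step that came with 3,5-dimethoxyphenyl replacing 2,3,4-trimethoxyphenyl. Within the data shown here, two compounds establish no pattern, and no measured compound carries the 4-methoxyphenyl group. Even so, that group is contained within the 2,3,4-trimethoxyphenyl of compound 1, but not within the 3,5-dimethoxyphenyl of compound 2. A modest move toward a lower number in this assay is therefore expected, probably smaller than the measured step, though it may not clear the scatter by much. The estimated step is a 2.5-fold lower number from compound 2 to compound 3 (0.40 log units; beyond the scatter). Compound 3 is estimated at 12000 nM, with an expected range from 3500 nM to 40000 nM.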

Compound 3, half-maximal inhibitory concentration: 5070 nM
Compound 3: middle estimate off by 2.4-fold (0.37 log units), on the high side, within the range that was stated.
By their numbers in this assay, from the lowest: compounds 1 and 3 (each within the scatter of the next); then compound 2.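

In this assay, 4-methoxyphenyl in place of 3,5-dimethoxyphenyl on a double-bonded chain carbon bound to a double-bonded chain carbon gives a 6.0-fold lower number from compound 2 to compound 3 (0.78 log units; beyond the scatter), so the entering group, with fewer heavy atoms and one hydrogen-bond acceptor fewer, comes with the lower number in this pair. Set against 2,3,4-trimethoxyphenyl, the same group gives a 1.1-fold higher number from compound 1 to compound 3 (0.04 log units; within the scatter), and the count of methoxy groups does not track the read-out across these three compounds: compound 2, which carries more of them than compound 3 and fewer than compound 1, stands apart from both. Nothing measured here gives a reason for these differences.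

Going by these compounds, it remains open whether a plain phenyl, a 3-methoxyphenyl or a 4-hydroxyphenyl at this place would fall with compounds 1 and 3 or with compound 2 in this assay. Also open, on these data alone, is whether a group other than methoxy, such as a fluorine or a dimethylamino group, would give a similar number on the same ring.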